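The source may hold more compounds than are shown below. What is called first, only, known or untested is meant among the compounds shown, and "the series" means these compounds.

Compound 1 `Cc1ccc(-c2cc(/N=C3/NC(=O)CS3)cs2)cc1` opens the set; in a functional assay on HCT-116 cells (Homo sapiens) for cytotoxicity, read by MTT assay, with a stated time of 72 h (a lower number here means a stronger inhibitor, a higher number a weaker inhibitor), compound 1 gives > 50000 nM, which is a limit of the assay rather than a number. Compound 2 `O=C1CS/C(=N\c2csc(-c3ccc(Cl)cc3)c2)N1` carries a chloro in place of methyl on an aromatic carbon, and in this assay compound 2 gives > 50000 nM, again a limit of the assay. The step that the two limits leave unreadable from compound 1 to compound 2 therefore cannot be read, since both of its ends sit at the limit of > 50000 nM in this assay, at which 2 of the 3 values shown sit. Compound 3 `O=C1N/C(=N/c2csc(-c3ccc(Cl)cc3)c2)S/C1=C\c1ccccc1` extends the shared core of compound 2 by a phenyl arm; in this assay compound 3 gives 11200 nM. Going by the values given here, this is the only number among the three values shown. Compound 4 `COc1ccc(/C=C2\S/C(=N\c3csc(-c4ccc(Cl)cc4)c3)NC2=O)cc1` differs from compound 3 by methoxy in place of hydrogen on an aromatic carbon. Among the compounds with values here, no measured step touches the phenyl arm, and the one measured step, from compound 1 to compound 2, is unreadable, so nothing among the measured compounds sets a size or a direction for this change. The step of a 1.2-fold lower number from compound 3 to compound 4 (0.09 log units; within the scatter) is accordingly expected to stay within the scatter of repeated measurements. The estimate for compound 4 in this assay is 9000 nM, with a likely range from 3000 nM to 30000 nM.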

Compound 4, half-maximal inhibitory concentration: 1300 nM
Compound 4: the middle estimate sits 6.9-fold (0.84 log units) above what was measured; measured number below the stated range.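

In this assay, going by these compounds alone, methoxy in place of hydrogen gives an 8.6-fold lower number from compound 3 to compound 4 (0.94 log units; beyond the scatter), the only step in this set so far that can be read as a size and a direction. It shows that the phenyl arm is not a silent part of the molecule: a change on an aromatic carbon of that six-membered ring, para to a large group, moves the number by more than repeated measurements would. The earlier compounds could not show this, as compound 1 and compound 2 are both held at a limit of the assay rather than a number, which leaves the step between them unreadable: the limit of > 50000 nM in this assay, at which 2 of the 4 values shown sit.

As far as these compounds go, what stays open is whether this gain belongs to methoxy itself or would come with other groups at the same place, such as a hydroxyl, an ethoxy or an amine, and whether the same group would do the same at another place on this ring. Only one such change is shown, on a core carrying chloro, so it also remains unknown whether phenyl to 4-methoxyphenyl would give a step of similar size with methyl in place of that chloro.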